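The source may hold more compounds than are shown below. What is called first, only, known or untested is meant among the compounds shown, and "the series" means these compounds.

Compound 1 `CCCc1nc(-c2ccccc2)c(CNCCCN2CCN(c3ccccc3OC)CC2)o1` and compound 2 `CCCc1nc(-c2ccccc2)c(CNCCN2CCN(c3ccccc3)CC2)o1` were both tested in an assay on HEK293 cells for inhibition of Voltage-dependent T-type calcium channel subunit alpha-1G (Homo sapiens), read by fluorescence, tested at 10 uM; on this read-out lower numbers stand for less inhibition and higher numbers for more inhibition at the one concentration tested (going by the name of the read-out). Compound 1 gives 41%, the lower of the two numbers, while compound 2 gives 54.3%, which stands beyond the scatter above it. Compound 3 `CCCc1nc(-c2ccccc2)c(CNCCCN2CCN(c3cccc(F)c3)CC2)o1` has not yet been measured in this assay. It differs from compound 1 by 3-fluorophenyl in place of 2-methoxyphenyl on an amine nitrogen in a ring. Among the compounds with values here, no measured pair shows this change, so the expected step of a number 4 percentage points higher from compound 1 to compound 3 (within the scatter) is judged small and probably within the scatter, with no firm direction. Compound 3 is therefore estimated to give 45%, with a range from 20% to 70%.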

Compound 3, a percentage reported as inhibition, at one concentration (the size of the read-out at that concentration, not a potency): 68.9%
Estimate against measurement, compound 3: 23.9 percentage points below; the range from low to high includes it.
By their numbers in this assay, from the lowest: compound 1; then compound 2; then compound 3.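

In this assay, 3-fluorophenyl in place of 2-methoxyphenyl on the amine nitrogen in the ring gives a number 27.9 percentage points higher from compound 1 to compound 3 (beyond the scatter). This is the first single-place change shown, and it shows that the aryl group at this position can move the read-out beyond the scatter. Nothing given here accounts for the step.

The compounds shown leave open whether the step follows the fluorine, the loss of the methoxy group, or the place of either on the phenyl ring. Groups such as 2-fluorophenyl and 3-methoxyphenyl at this position would separate these readings.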